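Swapping the Aryl Group on a Sulfonyl Bridge

The source may hold more compounds than are shown below. What is called first, only, known or untested is meant among the compounds shown, and "the series" means these compounds.

Measured compounds:
- compound 1, `CC(O)(C(=O)Nc1ccc(C#N)c(S(=O)(=O)c2ccccc2)c1)C(F)(F)F`: 2600 nM
- compound 2, `CC(O)(C(=O)Nc1ccc(S(=O)(=O)c2ccccc2O)cc1)C(F)(F)F`: 3090 nM

Both compounds were tested in a functional assay (Cavia porcellus) with sulfonylurea receptors; K-ATP channels (Homo sapiens) as the target; a lower number here means a stronger inhibitor, a higher number a weaker inhibitor. Compound 1 gives 2600 nM, and compound 2 gives 3090 nM; the two values lie within the usual scatter of each other, so neither compound can be said to be the stronger inhibitor on these numbers.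

Compound 3, `Cc1cccc(S(=O)(=O)c2ccc(NC(=O)C(C)(O)C(F)(F)F)cc2)c1`, has not yet been measured. It differs from compound 2 in one place: 3-methylphenyl in place of 2-hydroxyphenyl on a sulfonyl sulfur. Within the data shown here, no measured pair shows the effect of this exchange, so there is no known step to lean on. In this assay the expected change from compound 2 to compound 3 is a 1.2-fold lower number from compound 2 to compound 3 (0.09 log units; within the scatter), which amounts to nothing beyond the scatter in either direction. The estimate for compound 3 in this assay is therefore 2500 nM, with a range from 900 nM to 7000 nM.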

Compound 3, half-maximal inhibitory concentration: 2200 nM
The estimate for compound 3 lay 1.1-fold (0.06 log units) above the measured number; low and high end bracket the measured number.
By their numbers in this assay, from the lowest: compounds 3, 1 and 2 (each within the scatter of the next).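

In this assay, among these compounds, putting 3-methylphenyl in place of 2-hydroxyphenyl gives a 1.4-fold lower number from compound 2 to compound 3 (0.15 log units; within the scatter) and is the first direct reading of an exchange on this sulfonyl sulfur. The group that leaves carries a hydrogen-bond donor and a hydrogen-bond acceptor and the group that enters carries neither, yet the two compounds cannot be told apart in this measurement. For this one pair, then, losing the hydroxyl and gaining a methyl leaves no readable mark on the number, although a single exchange cannot speak for this position as a whole, and no data here bear on why the two groups read alike.

Still open, from the compounds shown here alone, is whether an amine or a carboxylic acid on that aryl ring would also read alike. So too is whether a butyl chain in place of the whole aryl group on the sulfonyl sulfur would.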